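Pyridinylmethyl for methylphenyl on the thienopyrimidine amine

This account rests on a few compounds, and the source may have more. Where it says the series, first, only, none or still open, it means among the compounds named here.

The set holds two measured compounds. In a functional assay on L02 cells (Homo sapiens) for inhibition, read by Griess assay, with stated times of 1 h and 24 h (on this read-out lower numbers stand for stronger inhibition and higher numbers for weaker inhibition), compound 1 `CCCc1nn(C)c2c(NC(C)C)nc(/C=C/c3ccc[n+]([O-])c3)nc12` gives 324000 nM. Compound 2 `COc1cc(/C=C/c2nc(Nc3ccc(C)cc3)c3sccc3n2)cc(OC)c1OC` has in this assay only a limit of the measurement, < 40000 nM, not a number; this is the limit of < 40000 nM in this assay, at which 1 of the 2 values shown sits. Compound 2 therefore stands at the limit, and nothing more about its position on the numbers is known.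

Compound 3 `COc1cc(/C=C/c2nc(NCc3ccncc3)c3sccc3n2)cc(OC)c1OC` differs from compound 2 in one place: (pyridin-4-yl)methyl in place of 4-methylphenyl on a nitrogen on an aromatic ring. Within the data shown here, no step between measured compounds is available to size this change, so no direction beyond the usual scatter is expected from compound 2 to compound 3. The expected step in this assay is a step that the limit leaves unreadable from compound 2 to compound 3, and since compound 2 is itself only known as a limit, compound 3 may again return a limit. On these grounds compound 3 is estimated at 30000 nM, with a range from 8000 nM to 80000 nM.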

Compound 3, half-maximal inhibitory concentration: 374000 nM
The estimate for compound 3 lay 12-fold (1.10 log units) below the measured number, outside the stated range (above it).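

In this assay, exchanging 4-methylphenyl for (pyridin-4-yl)methyl on a nitrogen on an aromatic ring gives an at least 9.3-fold higher number from compound 2 to compound 3 (0.97 log units; beyond the scatter), which on this read-out means weaker inhibition. Among these compounds, the earlier compounds offered no step at all, so this is the first sign that the group on this nitrogen can move the number beyond the scatter. The size of the step is only a lower bound, since the value for compound 2 is a limit and not a number: the limit of < 40000 nM in this assay, at which 1 of the 3 values shown sits.

The exchange alters both the ring, which gains a nitrogen, and the way that ring is attached, so compound 2 and compound 3 alone cannot say which of the two carries the step. On these data alone, a benzyl group on the same nitrogen would separate these two differences, and its effect remains open.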